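Adding a Ring-Bearing Chain to the Amide Nitrogen of Compound 1

The source may report more compounds than this note shows. Statements on the series, on what has been measured and on what is new or still open speak of the compounds shown alone.

Compound 1 `CCc1cnc(N2CCC(c3nc(COc4ccc(/C=C5\CC(=O)NC5=O)cc4F)cs3)CC2)nc1` was examined in a functional assay on cells for agonist activity at Glucose-dependent insulinotropic receptor (Homo sapiens), read by a luciferase reporter, with a stated time of 6 h (on this read-out higher numbers stand for an effect only at larger amounts of compound and lower numbers for an effect already at smaller amounts), where compound 1 gives 49 nM. Among the two numbers available it holds the lowest; the nearest is compound 3 `CCc1cnc(N2CCC(c3nc(COc4ccc(/C=C5\CCNC5=O)cc4F)cs3)CC2)nc1`, for which this assay returns 100 nM. That difference, a 2.0-fold higher number from compound 1 to compound 3 (0.31 log units; beyond the scatter), accompanies the loss of one carbonyl from the five-membered ring, a change at a different place from the one now considered. Compound 2 `CCc1cnc(N2CCC(c3nc(COc4ccc(/C=C5\CC(=S)N(CC(=O)O)C5=O)cc4F)cs3)CC2)nc1`, which carries both a substituent on the ring nitrogen and a further alteration of the ring, has no number in this assay ("not determined" (no result reported)), so it can say nothing about either change.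

Compound 4 `CCc1cnc(N2CCC(c3nc(COc4ccc(/C=C5\CC(=O)N(CC6CCOCC6)C5=O)cc4F)cs3)CC2)nc1` differs from compound 1 by (oxan-4-yl)methyl in place of hydrogen on an amide-type nitrogen in a ring. Among the compounds with values here, no measured step touches this nitrogen: the single step available concerns a ring carbonyl, and it was modest. The data therefore give no direct guide to the size or direction of the new step, and the expectation for compound 4 is that the change, a 1.6-fold higher number from compound 1 to compound 4 (0.21 log units; within the scatter), stays near or only a little beyond the scatter, with a wide allowance in both directions. Compound 4 is accordingly estimated at 80 nM, expected to lie between 25 nM and 300 nM.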

Compound 4, half-maximal effective concentration: 240 nM
The estimate for compound 4 lay 3.0-fold (0.48 log units) below the measured number; the measured number falls inside the stated range.
By their numbers in this assay, from the lowest: compound 1; then compound 3; then compound 4.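

In this assay, within the data shown here, this is the first readable change at the amide-type nitrogen in the five-membered ring: (oxan-4-yl)methyl in place of hydrogen gives a 4.9-fold higher number from compound 1 to compound 4 (0.69 log units; beyond the scatter), a step beyond the scatter. The amide hydrogen of compound 1 is therefore not needed for a response in this assay, since compound 4 still gives a number, but this substituent moves that number upward, so that the effect appears only at larger amounts of compound. The material shown contains no measurement that explains this step.

With a single readable substituent at this nitrogen, the compounds shown cannot separate the contribution of the six-membered ring from that of its linking carbon, nor show whether a small methyl group or a longer chain ending in an amine would give a smaller or larger step. They also leave open whether (oxan-4-yl)methyl would have the same effect on the ring of compound 3, which has one carbonyl fewer, while compound 2 has no number and adds nothing on this nitrogen.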